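The source may hold more compounds than are shown below. What is called first, only, known or untested is meant among the compounds shown, and "the series" means these compounds.

Compound 1 `CC(C)[C@H](NC(=O)COc1cccc2ccccc12)C(=O)N[C@@H](CC(=O)O)C(=O)COc1cccc(C(F)(F)F)c1`: > 100000 nM (a limit)
Compound 2 `CC(C)[C@H](NC(=O)COc1cccc2ccccc12)C(=O)N[C@@H](CC(=O)O)C(=O)COc1c(F)cccc1F`: 2040 nM

Within the data shown here, in a functional assay on Jurkat cells (Homo sapiens) (on this read-out lower numbers stand for stronger inhibition and higher numbers for weaker inhibition), compound 2 gives 2040 nM, the only exact number so far. Compound 1 reaches only a limit of the assay, > 100000 nM.

Compound 3 `CC(C)[C@H](NC(=O)COc1cccc2ccccc12)C(=O)N[C@@H](CC(=O)O)C(=O)COc1cc(F)cc(F)c1` has the same atoms as compound 2, joined differently: 3,5-difluorophenyl in place of 2,6-difluorophenyl on an oxygen on a saturated carbon. It carries 3,5-difluorophenyl in place of 2,6-difluorophenyl on an oxygen on a saturated carbon.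

Among the measured compounds shown here, one measured step bears on this place: an at least 49-fold lower number from compound 1 to compound 2 (1.69 log units; beyond the scatter). That large step, which reached 2,6-difluorophenyl from 3-(trifluoromethyl)phenyl, shows that the group here can matter greatly. Moving away from 2,6-difluorophenyl is therefore expected to weaken inhibition, though probably less sharply, since the fluorines stay. The expected change is a 4.9-fold higher number from compound 2 to compound 3 (0.69 log units; beyond the scatter). The estimate for compound 3 is 10000 nM, with an expected range from 2500 nM to 60000 nM.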

Compound 3, half-maximal inhibitory concentration: > 100000 nM
Compound 3: a limit, no number (the forecaster's own chance of this, stated with the estimate: 15%); middle value at least 10-fold (1.00 log units) from the limit.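

In this assay, compound 3 gives > 100000 nM, which is a limit of the assay and not a number. Moving the two fluorines from 2,6-difluorophenyl to 3,5-difluorophenyl, with no atom gained or lost, gives an at least 49-fold higher number from compound 2 to compound 3 (1.69 log units; beyond the scatter), so carrying fluorine on this ring is not enough and where it sits decides the outcome. The steps between compounds at the limit cannot be read: the limit of > 100000 nM in this assay, at which 2 of the 3 values shown sit.

As far as these compounds go, only the 2,6-difluorophenyl group gives an exact number here, so it remains open how much of its effect comes from either fluorine alone and whether fluorine is needed at all. An unsubstituted phenyl, a 2-fluorophenyl or a 2,6-dichlorophenyl group on the same oxygen would address these questions.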